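Series notes: capping the distal amine on the azetidine substituent

The compounds below may be only part of what the source reports. "The series", "measured", "known", "first", "only" and "open" are said of these compounds alone.

Measured so far:
compound 1, `O=C1CCC(CCN2CC(N3CCNCC3)C2)(c2ccc(Cl)c(Cl)c2)CN1Cc1ccccc1`, 5.01 nM
compound 2, `CC(=O)N1CCN(C2CN(CCC3(c4ccc(Cl)c(Cl)c4)CCC(=O)N(Cc4ccccc4)C3)C2)CC1`, 1.59 nM
compound 3, `O=C1CCC(CCN2CC(N3CCNCC3)C2)(c2ccc(Cl)c(Cl)c2)CN1CC1CC1`, 12.6 nM

All three were run in an assay on isolated protein (artery, Oryctolagus cuniculus) with Substance-P receptor (Homo sapiens) as the target; a higher number here means weaker binding, a lower number tighter binding. Compound 3 carries the highest number of the three: compound 1 sits nearer to it, a 2.5-fold higher number from compound 1 to compound 3 (0.40 log units; beyond the scatter), while compound 2 sits furthest from it, and both gaps are beyond the scatter.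

Compound 4, `CS(=O)(=O)NC1CCN(C2CN(CCC3(c4ccc(Cl)c(Cl)c4)CCC(=O)N(CC4CC4)C3)C2)CC1`, has not yet been measured. It keeps the cyclopropyl of compound 3 and differs only at the azetidine: 4-(methanesulfonamido)piperidin-1-yl in place of piperazin-1-yl on a saturated ring carbon. Within the data shown here, no measured pair shows this exact exchange. The step that bears on it most closely is the one at the same distal amine, where an acetyl cap on the piperazine gave a 3.2-fold lower number from compound 1 to compound 2 (0.50 log units; beyond the scatter). Compound 4 likewise converts that amine into a neutral, hydrogen-bond-donating group, so a step of similar direction and size is expected in this assay, without the two structures being equivalent.

On that basis compound 4 is expected to give 5 nM, within 2 nM to 15 nM, the estimate meaning a 2.5-fold lower number from compound 3 to compound 4 (0.40 log units; beyond the scatter).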

Compound 4, dissociation constant: 10 nM
Beside the measured number, compound 4's estimate is 2.0-fold (0.30 log units) below it; the measured number falls inside the stated range.
By their numbers in this assay, from the lowest: compound 2; then compounds 1, 4 and 3 (each within the scatter of the next, the first and the last beyond it).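

In this assay, the exchange of piperazin-1-yl for 4-(methanesulfonamido)piperidin-1-yl on a saturated ring carbon of the four-membered non-aromatic ring gives a 1.3-fold lower number from compound 3 to compound 4 (0.10 log units; within the scatter), so this position accepts the larger group with the cyclopropyl kept, and no change can be read. Among these compounds, until now, the only step at this end of the molecule was a 3.2-fold lower number from compound 1 to compound 2 (0.50 log units; beyond the scatter), which lies beyond the scatter, so a change here does not always produce a readable step, although the two steps differ in both the entering group and the group on the amide-type nitrogen. Nothing available here explains why the new step stays within the scatter.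

Going by these compounds, it remains open whether 4-(methanesulfonamido)piperidin-1-yl would give a readable step with the phenyl-bearing group of compound 1 in place of the cyclopropyl, which would separate the effect of the entering group from that of its background. A methanesulfonyl group placed directly on the piperazine nitrogen, or a 4-acetamidopiperidin-1-yl group, would also show whether the sulfonamide or the piperidine ring governs the result at this position.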